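The compounds below may be only part of what the source reports. "The series", "measured", "known", "first", "only" and "open" are said of these compounds alone.

Measured compounds:
Compound 1, `CCOCCCNC(=O)c1csc(Nc2ccc(Cl)cc2)n1`, in an ADME assay on MDCK cells (Canis lupus familiaris) for cytotoxicity, with a stated time of 48 h (a lower number here means that less compound is tolerated, a higher number that more compound is tolerated), gives > 100000 nM; this value is a limit of the assay, not a number.
Compound 2, `CC(C)OCCCNC(=O)c1csc(Nc2ccc(Cl)c(F)c2)n1`, in this assay gives > 100000 nM; this too is a limit of the assay rather than a measured number.

Among the measured compounds shown here, compound 2 therefore stands only on a limit: no exact concentration is known for it, and the single other value shown is a limit as well, summed up as the limit of > 100000 nM in this assay, at which 2 of the 2 values shown sit. For the measured compounds named here, no step between measured compounds can be computed here, since the two differ in more than one place.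

Compound 3, `CCOCCCNC(=O)c1csc(Nc2ccc(Cl)c(F)c2)n1`, has not yet been measured in this assay. It differs from compound 2 by hydrogen in place of methyl on a saturated chain carbon bound to an oxygen on a saturated carbon and a saturated chain carbon. The remaining part of the molecule is unchanged.

Both measured compounds sit at the same limit, and nothing in the shown values points to a change in either direction, so compound 3 is expected to sit at that limit too. The expected step from compound 2 to compound 3 is a step that the limit leaves unreadable from compound 2 to compound 3, which is none beyond the usual scatter. For compound 3 the estimate in this assay is 150000 nM, with an expected range from 70000 nM to 400000 nM.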

Compound 3, half-maximal cytotoxic concentration: > 100000 nM
Compound 3: no number, only a limit (the forecaster's own chance of this, stated with the estimate: 85%); the middle value lies beyond the limit too.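

The steps from compound 2 to compound 3 and from compound 1 to compound 3 cannot be read, because all three compounds rest on a limit of the assay rather than a number: the limit of > 100000 nM in this assay, at which 3 of the 3 values shown sit.

The compounds shown leave open at what concentration each would harm the cells in this assay, and whether isopropoxy to ethoxy or fluoro in place of hydrogen changes that concentration at all.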